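A few compounds are considered here, and "the series" means these few. Any claim that something is new, unique, unknown or untested is made for them only; others in the source may bear on it.

In a functional assay on HeLa cells (Homo sapiens) for cytotoxicity, read by resazurin assay, with a stated time of 72 h (on this read-out higher numbers stand for weaker inhibition and lower numbers for stronger inhibition), compound 3 (`COc1cc(/C=C/C(=O)OCCCCCO[N+](=O)[O-])ccc1O`) gives 13400 nM which sits within the scatter of compound 1 (`COc1cc(/C=C/C(=O)OCCCCCCO[N+](=O)[O-])ccc1O`) at 16300 nM and well above compound 2 (`COc1cc(/C=C/C(=O)OCCCO[N+](=O)[O-])ccc1OCCCO[N+](=O)[O-]`) at 3620 nM on the same scale. Compound 4 (`COc1cc(/C=C/C(=O)OCCCO[N+](=O)[O-])ccc1O`) has not yet been measured. It differs from compound 3 by a shorter chain: nitrooxy in place of 2-(nitrooxy)ethyl on a saturated chain carbon, three bonds along the chain from an oxygen next to a carbonyl group with nitrooxy in place of 2-(nitrooxy)ethyl on a saturated chain carbon, three bonds along the chain from an oxygen next to a carbonyl group. For the measured compounds named here, one measured step bears on this, since it also puts nitrooxy in place of a longer group on the chain: a 1.2-fold lower number from compound 1 to compound 3 (0.09 log units; within the scatter) for nitrooxy in place of (nitrooxy)methyl. The change to compound 4 removes more of the chain, so that single small step is only a rough guide. The expected change is still small, an estimated 1.2-fold lower number from compound 3 to compound 4 (0.07 log units; within the scatter) and so nothing clearly beyond the scatter. In this assay the estimate for compound 4 is 11500 nM with 5500 nM to 24000 nM as the expected range.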

Compound 4, half-maximal inhibitory concentration: 6700 nM
Beside the measured number, compound 4's estimate is 1.7-fold (0.23 log units) above it, within the range that was stated.
By their numbers in this assay, from the lowest: compounds 2, 4, 3 and 1 (each within the scatter of the next, the first and the last beyond it).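

In this assay, the length of the chain carrying the nitrooxy group now has a visible effect: a 2.4-fold lower number from compound 1 to compound 4 (0.39 log units; beyond the scatter), a modest step beyond the scatter, with nitrooxy in place of 3-(nitrooxy)propyl. The smaller cut, nitrooxy in place of 2-(nitrooxy)ethyl, gives a 2.0-fold lower number from compound 3 to compound 4 (0.30 log units; within the scatter), which stays within the scatter, so among these compounds the effect appears only across the full span of chain lengths. On the oxygen on the aromatic ring, hydrogen in place of 3-(nitrooxy)propyl gives a 1.9-fold higher number from compound 2 to compound 4 (0.27 log units; within the scatter), also within the scatter, so that second chain makes no clear difference here.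

Nothing in the data shown explains these differences. Also open, as far as these compounds go, is how an amine or a carboxylic acid in place of nitrooxy would read on this chain.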